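An Ethoxy Group on the Phenyl of Compound 1

The source may report more compounds than this note shows. Statements on the series, on what has been measured and on what is new or still open speak of the compounds shown alone.

For the measured compounds named here, compound 1 `COc1cc(C(=O)c2sc3ccccc3c2-c2ccccc2)cc(OC)c1OC` is the one compound with an actual number in a functional assay on HL-60 cells (Homo sapiens) for antiproliferative activity, read by MTT assay, with a stated time of 72 h; a higher number here means a weaker inhibitor, a lower number a stronger inhibitor: compound 1 gives 1700 nM. Compound 2 `COc1ccc(OC)c(-c2c(C(=O)c3cc(OC)c(OC)c(OC)c3)sc3ccccc23)c1`, which carries 2,5-dimethoxyphenyl in place of phenyl on an aromatic carbon, reaches only the limit of this assay, > 10000 nM. Going by the values given here, that step, an at least 5.8-fold higher number from compound 1 to compound 2 (0.76 log units; beyond the scatter), is the only comparison available, and its size is known only as a lower bound because of the limit of > 10000 nM in this assay, at which 1 of the 2 values shown sits. Compound 3 `CCOc1ccc(-c2c(C(=O)c3cc(OC)c(OC)c(OC)c3)sc3ccccc23)cc1` has not yet been measured. It differs from compound 1 by ethoxy in place of hydrogen on an aromatic carbon. The step to compound 2 bears on this change only loosely: there the phenyl took on two methoxy groups, here it takes a single ethoxy, and a single change to the same ring cannot be read straight from a double one. Among the compounds with values here, the one comparison at hand points toward a weaker compound, so a modest rise in this assay is expected, a 1.5-fold higher number from compound 1 to compound 3 (0.17 log units; within the scatter), kept small since the two substitution patterns differ. Compound 3 is therefore expected to give 2500 nM, within 800 nM to 8000 nM.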

Compound 3, half-maximal inhibitory concentration: 3500 nM
Compound 3: middle estimate off by 1.4-fold (0.15 log units), on the low side; the range from low to high includes it.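

In this assay, ethoxy in place of hydrogen, on the aromatic carbon para to a large group, gives a 2.1-fold higher number from compound 1 to compound 3 (0.31 log units; beyond the scatter), so a single added group at this position already separates the two compounds beyond the scatter, though only modestly. The substituted phenyl now also has an actual value rather than a limit alone, and 4-ethoxyphenyl in place of 2,5-dimethoxyphenyl gives an at least 2.8-fold lower number from compound 2 to compound 3 (0.45 log units; beyond the scatter), which shows that not every substituted phenyl on this core behaves alike. The size of that second step is known only as a lower bound, set by a limit: the limit of > 10000 nM in this assay, at which 1 of the 3 values shown sits.

The compounds shown leave open whether the rise belongs to ethoxy itself or would come with any group at this carbon, such as a methoxy, a longer propoxy chain, a fluorine or an amine. They also leave open how the change from phenyl to 2,5-dimethoxyphenyl divides between its two methoxy groups, since neither methoxy appears on the phenyl alone.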